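This account rests on a few compounds, and the source may have more. Where it says the series, first, only, none or still open, it means among the compounds named here.

Of the compounds shown here, two of a shared core have been measured so far. Compound 1 `CN1CCN(CCCS(=O)(=O)c2ccc3nc(NC(=O)NC(=O)c4cc(-n5cccn5)c(Cl)cc4Cl)sc3c2)CC1` in an assay on HEK293 cells for displacement of a labelled ligand from growth hormone secretagogue receptor type 1 (Homo sapiens), with a stated time of 60 min (a lower number here means a stronger inhibitor, a higher number a weaker inhibitor), gives 0.31 nM. Compound 2 `CN1CCN(CCCS(=O)(=O)c2ccc3nc(NC(=O)NC(=O)c4cc(-n5cccc5)ccc4Cl)sc3c2)CC1` in this assay gives 0.15 nM, the lower of the two numbers; the gap from compound 1 to compound 2 is beyond the usual scatter, so compound 2 stands as the stronger of the pair.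

Compound 3 `CCOc1ccc(Cl)c(C(=O)NC(=O)Nc2nc3ccc(S(=O)(=O)CCCN4CCN(C)CC4)cc3s2)c1` is not yet measured. It differs from compound 2 in one place: ethoxy in place of 1H-pyrrol-1-yl on an aromatic carbon. Going by the values given here, no measured pair shows this exchange, so its effect is unknown from the numbers at hand. The expected step from compound 2 to compound 3 in this assay is a 2.7-fold higher number from compound 2 to compound 3 (0.43 log units; beyond the scatter), a modest move toward a higher number that may or may not exceed the scatter. For compound 3 the estimated value in this assay is 0.4 nM, with a range from 0.12 nM to 1.5 nM.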

Compound 3, half-maximal inhibitory concentration: 0.31 nM
Estimate against measurement, compound 3: 1.3-fold (0.11 log units) above, and the stated range covers the measured number.
By their numbers in this assay, from the lowest: compound 2; then compounds 1 and 3 (each within the scatter of the next).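

In this assay the exchange of 1H-pyrrol-1-yl for ethoxy, on an aromatic carbon meta to a large group and para to a chloro group, gives a 2.1-fold higher number from compound 2 to compound 3 (0.32 log units; beyond the scatter) and so shows that this position responds to the change, though only modestly. The five-membered aromatic ring is not required for a strong result here, since compound 3 has no ring in this group and still gives 0.31 nM in this assay with fewer heavy atoms at this place. Nothing at hand accounts for the direction or size of this step.

This single exchange removes the ring and introduces the oxygen together, so the compounds shown cannot separate those two changes. As far as these compounds go, how a methoxy group, a longer alkoxy chain, an amine or a carboxylic acid would fare at this position remains open.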